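A few compounds are considered here, and "the series" means these few. Any claim that something is new, unique, unknown or untested is made for them only; others in the source may bear on it.

Measured compounds:
compound 1 `CCN(CC)S(=O)(=O)c1ccc(S(=O)(=O)N2CCC[C@@H](C(=O)N3CCN(c4nc(C)no4)CC3)C2)cc1` gives 200 nM
compound 2 `CCN(CC)S(=O)(=O)c1ccc(S(=O)(=O)N2CCC[C@@H](C(=O)N3CCN(C(=O)OC(C)(C)C)CC3)C2)cc1` gives 10 nM
compound 3 `CCN(CC)S(=O)(=O)c1ccc(S(=O)(=O)N2CCC[C@@H](C(=O)N3CCN(c4nc(C(F)(F)F)no4)CC3)C2)cc1` gives 60 nM

In a functional assay on MIA PaCa-2 cells (Homo sapiens) for inhibition, read by MTT assay, with a stated time of 3 days (a higher number here means a weaker inhibitor, a lower number a stronger inhibitor), compound 1 stands with the highest number of the three; the steps away from it are a 3.3-fold lower number from compound 1 to compound 3 (0.52 log units; beyond the scatter) and a 20-fold lower number from compound 1 to compound 2 (1.30 log units; beyond the scatter). Compound 4 `CCN(CC)S(=O)(=O)c1ccc(S(=O)(=O)N2CCC[C@@H](C(=O)NC)C2)cc1` differs from compound 1 in one place: methylamino in place of 4-(3-methyl-1,2,4-oxadiazol-5-yl)piperazin-1-yl on a carbonyl carbon. Within the data shown here, no measured step removes the whole piperazine; the two steps on the amine nitrogen in a ring, a 20-fold lower number from compound 1 to compound 2 (1.30 log units; beyond the scatter) and a 6.0-fold higher number from compound 2 to compound 3 (0.78 log units; beyond the scatter), show that this side of the carbonyl shifts the number strongly, and the remaining measured step, a 3.3-fold lower number from compound 1 to compound 3 (0.52 log units; beyond the scatter), is modest. Cutting the group down to methylamino is expected to raise the number beyond the scatter. Compound 4 is therefore estimated at 1000 nM, within 200 nM to 5000 nM, an expected step of a 5.0-fold higher number from compound 1 to compound 4 (0.70 log units; beyond the scatter).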

Compound 4, half-maximal inhibitory concentration: 2000 nM
Compound 4: the middle estimate sits 2.0-fold (0.30 log units) below what was measured; measured number inside the range.
By their numbers in this assay, from the lowest: compound 2; then compound 3; then compound 1; then compound 4.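

In this assay, among these compounds, the step of a 10-fold higher number from compound 1 to compound 4 (1.00 log units; beyond the scatter) comes from replacing the whole 4-(3-methyl-1,2,4-oxadiazol-5-yl)piperazin-1-yl group on the carbonyl carbon with methylamino, whereas the earlier steps only changed groups on that piperazine. This change removes both rings and adds an amide hydrogen, so the step cannot be assigned to either difference alone. No measurement shown explains the rise. Open, on these data alone, is how an unsubstituted piperazine would compare, which would separate the piperazine from the oxadiazole. Dimethylamino, which has no amide hydrogen, also remains open.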